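A few compounds are considered here, and "the series" means these few. Any claim that something is new, unique, unknown or untested is made for them only; others in the source may bear on it.

In a functional assay on the whole organism (blood) with Rattus norvegicus as the target, with stated times of 24 h and 1 h, at a dose of 15 mg/kg by the intraperitoneal route (on this read-out higher numbers stand for a stronger effect at the one dose given and lower numbers for a weaker effect), compound 2 `Cn1cccc(C(=O)NCCC2CCN(S(=O)(=O)NC(=O)NC[C@@H]3C[C@@H]4C=C[C@@H]3C4)CC2)c1=O` gives 40%. Among the compounds with values here, its only neighbour in the data is compound 1 `O=C(NC[C@@H]1C[C@@H]2C=C[C@@H]1C2)NS(=O)(=O)N1CCC(CCNC(=O)c2cc(Cl)ccn2)CC1`, which in this assay gives 46%; the step of a number 6 percentage points lower from compound 1 to compound 2 (within the scatter) lies within the scatter, so the two numbers cannot be told apart. Compound 3 `O=C(NC[C@@H]1C[C@@H]2C=C[C@@H]1C2)NS(=O)(=O)N1CCC(CCNC(=O)c2nc3ccccc3s2)CC1` has not yet been measured. It differs from compound 2 in one place: a group of 9 heavy atoms (7 carbon, 1 nitrogen, 1 sulfur; one five-membered aromatic ring with 2 hetero atoms, one six-membered aromatic ring of carbon only) in place of a group of 8 heavy atoms (6 carbon, 1 nitrogen, 1 oxygen; one six-membered aromatic ring with 1 hetero atom), on a carbonyl carbon. Within the data shown here, the one measured step that bears on this change is a number 6 percentage points lower from compound 1 to compound 2 (within the scatter), an exchange of the group on the same carbonyl carbon, and that step stayed within the scatter. On this evidence no change beyond the scatter is expected in this assay for compound 3, and the step of a number 3 percentage points higher from compound 2 to compound 3 (within the scatter) is estimated to be small. Compound 3 is therefore expected to give about 43%, in a range from 25% to 60%.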

Compound 3, a percentage reported as activity, at one dose (the size of the read-out at that dose, not a potency): 34%
Beside the measured number, compound 3's estimate is 9 percentage points above it; low and high end bracket the measured number.
By their numbers in this assay, from the lowest: compounds 3, 2 and 1 (each within the scatter of the next, the first and the last beyond it).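

On the carbonyl carbon, 1,3-benzothiazol-2-yl brings a five-membered aromatic ring and a six-membered aromatic ring of carbon only to this series, and in this assay its exchange for the group of the pyridone-bearing compound gives a step (a number 6 percentage points lower from compound 2 to compound 3 (within the scatter)) that cannot be told from no change. Set against 4-chloropyridin-2-yl, the same group gives the first step at this position to pass the scatter (a number 12 percentage points lower from compound 1 to compound 3 (beyond the scatter)), a modest one, so the position is not wholly indifferent to the group it carries, although the middle compound stays within the scatter of both others. Nothing measured here explains this gap.

The compounds shown leave open how a plain phenyl ring, a small alkyl group or a carboxylic acid on this carbonyl carbon would read in this assay. They also leave open whether the modest step would hold at any other dose.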